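This account rests on a few compounds, and the source may have more. Where it says the series, first, only, none or still open, it means among the compounds named here.

Of the compounds shown here, two have so far been measured in an assay on cells for antagonist activity at transient receptor potential cation channel subfamily V member 1 (Homo sapiens), read by FLIPR and calcium flux, with a stated time of 6 min; a lower number here means a stronger inhibitor, a higher number a weaker inhibitor. Compound 1 `CC(C(=O)NCc1ccc(C(C)(C)C)nc1SCCCN1CCCC1)c1ccc(NS(C)(=O)=O)c(F)c1` gives 17.1 nM in this assay. Compound 2 `CCCCN(C)c1cc(C(C)(C)C)ccc1CNC(=O)C(C)c1ccc(NS(C)(=O)=O)c(F)c1` gives 1 nM in this assay, the lowest of the two numbers, and its gap to compound 1 lies beyond the scatter of repeated measurements. The next compound, compound 3 `CC(C(=O)NCc1ccc(C(C)(C)C)cc1OCC(C)(C)C)c1ccc(NS(C)(=O)=O)c(F)c1`, has not yet been measured in this assay. It differs from compound 2 in a single place (neopentyloxy in place of butyl(methyl)amino on an aromatic carbon). Among the measured compounds shown here, no step between measured compounds that differ in one place is available, so the effect of this change cannot be read from the data at hand; in this assay a step of modest size toward a somewhat higher number, or none beyond the scatter, is expected. The step from compound 2 to compound 3 is estimated as a 2.5-fold higher number from compound 2 to compound 3 (0.40 log units; beyond the scatter). Compound 3 is therefore expected to give about 2.5 nM, within a range from 0.6 nM to 10 nM.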

Compound 3, inhibition constant: 3.8 nM
Beside the measured number, compound 3's estimate is 1.5-fold (0.18 log units) below it; low and high end bracket the measured number.
By their numbers in this assay, from the lowest: compound 2; then compound 3; then compound 1.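

In this assay, the aromatic carbon ortho to a large group and meta to a tert-butyl group takes neopentyloxy in place of butyl(methyl)amino with a step of a 3.8-fold higher number from compound 2 to compound 3 (0.58 log units; beyond the scatter) that is modest, though beyond the usual scatter. The two groups match in heavy-atom count and in hydrogen-bond donors and acceptors, and neither has a ring or a net charge, yet they are not interchangeable here, with butyl(methyl)amino giving the lower number. Nothing measured here accounts for this step.

This single pair changes both the atom attached to the ring and the shape of the chain, so it cannot show which of the two matters. A straight-chain butoxy group or a pyrrolidine ring at this position would help separate those two changes.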